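The compounds below may be only part of what the source reports. "The series", "measured", "known", "first", "only" and "open" are said of these compounds alone.

Compound 3, `CC(C)c1cccc(C(C)C)c1NC(=O)NCC1(c2ccc(C(F)(F)F)cc2)CCCC1`, gives 66 nM in an assay on microsomes for inhibition of acyl-CoA:cholesterol acyltransferase (Oryctolagus cuniculus); on this read-out lower numbers stand for stronger inhibition and higher numbers for weaker inhibition. Among the three measured compounds it gives the highest number: compound 1, `COc1ccc(C2(CNC(=O)Nc3c(C(C)C)cccc3C(C)C)CCCC2)cc1`, gives 31 nM in this assay, and compound 2, `CC(C)c1cccc(C(C)C)c1NC(=O)NCC1(c2cccc(OCc3ccccc3)c2)CCCC1`, gives 30 nM; the two of them sit within the scatter of each other, while compound 3 lies beyond the scatter from both. Going by the values given here, the only step that joins compound 3 to another measured compound is the one in which trifluoromethyl replaced methoxy on an aromatic carbon, and that step gave a 2.1-fold higher number from compound 1 to compound 3 (0.33 log units; beyond the scatter) in this assay.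

Compound 4, `CC(C)c1cccc(C(C)C)c1NC(=O)NCC1(c2cccc(N(C)C)c2)CCCC1`, differs from compound 3 in that (3-(dimethylamino)phenyl in place of 4-(trifluoromethyl)phenyl on a saturated ring carbon). Among the compounds with values here, the change removes the trifluoromethyl group whose arrival from compound 1 was the only measured step that raised the number, and it brings in a ring substituent of a kind not yet measured. The expectation for compound 4 is therefore that the number moves back down by a modest amount, because the step of a 2.1-fold higher number from compound 1 to compound 3 (0.33 log units; beyond the scatter) was itself modest, so that in this assay the step of a 1.9-fold lower number from compound 3 to compound 4 (0.28 log units; within the scatter) is expected. Compound 4 is thus estimated at 35 nM in this assay, with a range from 15 nM to 85 nM.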

Compound 4, half-maximal inhibitory concentration: 33 nM
The estimate for compound 4 lay 1.1-fold (0.03 log units) above the measured number; low and high end bracket the measured number.
By their numbers in this assay, from the lowest: compounds 2, 1, 4 and 3 (each within the scatter of the next, the first and the last beyond it).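

In this assay, the 3-(dimethylamino)phenyl group on the saturated ring carbon cannot be told apart from the groups of the two lower compounds: the printed comparisons are a 1.1-fold higher number from compound 2 to compound 4 (0.04 log units; within the scatter) and a 1.1-fold higher number from compound 1 to compound 4 (0.03 log units; within the scatter), which places this new ring substituent alongside benzyloxy and 4-methoxyphenyl. Leaving 4-(trifluoromethyl)phenyl gives a 2.0-fold lower number from compound 3 to compound 4 (0.30 log units; within the scatter), so this step, unlike the one that brought trifluoromethyl in from compound 1, does not clear the scatter, and compound 3 is separated from compound 2 and compound 1 but not from compound 4. Nothing measured here bears on the reason for these numbers.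

Compound 3 and compound 4 differ both in the group and in where it sits on the aromatic ring, so the compounds shown cannot separate the identity of the substituent from its location. Also open, from the compounds shown here alone, is how a carboxylic acid or a primary amine on that aromatic ring would read in this assay, and whether any substituent there would move the number clearly below the values seen so far.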